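Adding an acetoxy group to compound 2

The source may hold more compounds than are shown below. What is called first, only, known or untested is meant among the compounds shown, and "the series" means these compounds.

Compound 1 `CCOC(=O)C(COC(=O)c1ccccc1OC(C)=O)c1ccc(F)cc1` gives > 0.01 ug/mL
Compound 2 `CCOC(=O)C(COC(=O)c1ccccc1)c1ccc(C(F)(F)F)cc1` gives > 0.01 ug/mL

In a functional assay on HepG2 cells (Homo sapiens) for cytotoxicity, read by MTT assay, with a stated time of 72 h (a lower number here means a stronger inhibitor, a higher number a weaker inhibitor), compound 2 gives > 0.01 ug/mL as a limit, not a number. Compound 1 also gives a limit, so the measured picture is only this: the limit of > 0.01 ug/mL in this assay, at which 2 of the 2 values shown sit, and nothing finer. Compound 3 `CCOC(=O)C(COC(=O)c1ccccc1OC(C)=O)c1ccc(C(F)(F)F)cc1` differs from compound 2 by acetoxy in place of hydrogen on an aromatic carbon, ortho to a large group (acetoxy in place of hydrogen on an aromatic carbon). Going by the values given here, no measured pair shows this change, so the expected step in this assay is none beyond the scatter, in neither direction. This expectation amounts to an estimated step (a step that the limit leaves unreadable from compound 2 to compound 3) of no real size. For compound 3 the estimate is 0.012 ug/mL as a middle value, with an expected range from 0.004 ug/mL to 0.04 ug/mL around it.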

Compound 3, half-maximal inhibitory concentration: > 0.01 ug/mL
Compound 3: a limit, no number; the forecaster's own chance of this, stated with the estimate: 70%; the middle value is on the limit's open side.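

Going by these compounds alone, compound 3 gives only a limit, not a number, so no step from compound 1 or compound 2 to compound 3 can be read: the limit of > 0.01 ug/mL in this assay, at which 3 of the 3 values shown sit. The compounds shown leave open the true strength of all three, and whether acetoxy in place of hydrogen or trifluoromethyl in place of fluoro shifts it.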